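The compounds below may be only part of what the source reports. "The series", "measured", "known", "first", "only" and "open" are said of these compounds alone.

In a functional assay on HEK293 cells for agonist activity at G-protein coupled receptor 84 (Homo sapiens), read by calcium flux (a higher number here means that more compound is needed for the effect, a lower number that less compound is needed), three compounds built on one shared core have been measured. Compound 1 `N#CCCCCc1nc(O)cc(O)n1` gives only a limit of the assay, > 100000 nM (the limit of > 100000 nM in this assay, at which 1 of the 3 values shown sits). Compound 2 `CCCCCCc1nc(O)cc(O)n1` gives 454 nM, and compound 3 `CCCCCCCCCc1nc(O)cc(O)n1` gives 48.7 nM, the lowest of the two numbers; the step of a 9.3-fold lower number from compound 2 to compound 3 (0.97 log units; beyond the scatter) sets it apart, while an at least 220-fold lower number from compound 1 to compound 2 (2.34 log units; beyond the scatter) and an at least 2000-fold lower number from compound 1 to compound 3 (3.31 log units; beyond the scatter) mark the move away from the limit. Compound 4 `CCCCCCCc1nc(O)cc(O)n1` has not yet been measured. It differs from compound 3 in one place: hydrogen in place of ethyl on a saturated chain carbon, seven bonds along the chain from an aromatic carbon. Since the step of a 9.3-fold lower number from compound 2 to compound 3 (0.97 log units; beyond the scatter) came from lengthening that same chain, the shorter chain of compound 4 is expected to give a moderately higher number, a 4.1-fold higher number from compound 3 to compound 4 (0.61 log units; beyond the scatter). Compound 4 is therefore estimated at 200 nM, with a range from 70 nM to 600 nM.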

Compound 4, half-maximal effective concentration: 12.7 nM
Compound 4: the middle estimate sits 16-fold (1.20 log units) above what was measured, outside the stated range (below it).
By their numbers in this assay, from the lowest: compound 4; then compound 3; then compound 2. At a limit, above all of these: compound 1.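

Shortening the chain by removing ethyl at this carbon did not raise the number, as a 3.8-fold lower number from compound 3 to compound 4 (0.58 log units; beyond the scatter) shows, so a longer chain does not lower the number throughout. The number falls with a 36-fold lower number from compound 2 to compound 4 (1.55 log units; beyond the scatter), and compound 3, with the longest chain, goes against any steady fall. The step of an at least 7800-fold lower number from compound 1 to compound 4 (3.89 log units; beyond the scatter) starts from a limit of the assay and is only a bound: the limit of > 100000 nM in this assay, at which 1 of the 4 values shown sits.

On these data alone, what remains open is where between the chains of compound 2 and compound 3 the lowest number lies. Also open, as far as these compounds go, is how a longer chain, or an amine or a carboxylic acid at the chain end, would read.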